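The compounds below may be only part of what the source reports. "The series", "measured", "known", "first", "only" and "open" are said of these compounds alone.

Compound 1 `Cn1c(=O)c(S(=O)(=O)c2ccc(F)cc2F)cc2cnc(Nc3ccc4occc4c3)nc21` gives 15000 nM in a functional assay on K562 cells (Homo sapiens) for inhibition, read by trypan blue exclusion, with a stated time of 72 h; a lower number here means a stronger inhibitor, a higher number a weaker inhibitor. Compound 2 `Cn1c(=O)c(S(=O)(=O)c2ccc(F)cc2F)cc2cnc(Nc3ccc4c(c3)CC(=O)N4)nc21` gives 15000 nM.

Compound 2 stands level with compound 1 at the digits shown; the step of no change at the digits printed from compound 1 to compound 2 (within the scatter) lies within the scatter. Compound 3 `Cn1c(=O)c(S(=O)(=O)c2ccc(F)cc2F)cc2cnc(Nc3cnc4[nH]ccc4c3)nc21` differs from compound 2 by a group of 9 heavy atoms (7 carbon, 2 nitrogen; one five-membered aromatic ring with 1 hetero atom, one six-membered aromatic ring with 1 hetero atom) in place of a group of 10 heavy atoms (8 carbon, 1 nitrogen, 1 oxygen; one five-membered non-aromatic ring with 1 hetero atom, one six-membered aromatic ring of carbon only), on a nitrogen on an aromatic ring. Among the compounds with values here, the only measured step bearing on this position, no change at the digits printed from compound 1 to compound 2 (within the scatter), left the read-out unchanged when the group on that nitrogen was exchanged. The expected step is therefore no change at the digits printed from compound 2 to compound 3 (within the scatter), with no change beyond the scatter. Compound 3 is estimated at 15000 nM, within a range of 5000 nM to 45000 nM.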

Compound 3, half-maximal inhibitory concentration: 750 nM
Compound 3: the middle estimate sits 20-fold (1.30 log units) above what was measured; measured number below the stated range.
By their numbers in this assay, from the lowest: compound 3; then compounds 1 and 2 (each within the scatter of the next).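

The group on the nitrogen on an aromatic ring does matter in this assay: the exchange gives a 20-fold lower number from compound 2 to compound 3 (1.30 log units; beyond the scatter) and also a 20-fold lower number from compound 1 to compound 3 (1.30 log units; beyond the scatter). The level reading of compounds 1 and 2 therefore does not extend to every group at this position. Nothing measured here accounts for the difference.

Compound 3 differs from compounds 1 and 2 in the whole group, so the atoms that carry the step remain unresolved. Also open, going by these compounds, is whether an amine or a carboxylic acid on the entering group would keep the lower number.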